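This account rests on a few compounds, and the source may have more. Where it says the series, first, only, none or still open, it means among the compounds named here.

Compound 3 `CCOC(=O)c1ccc(-c2cc3nccc(-c4cc(OC)c(OC)c(OC)c4)n3n2)cc1` stands only at a limit in a functional assay on HCT-116 cells (Homo sapiens) for inhibition, read by CCK-8 assay, with a stated time of 48 h (a lower number here means a stronger inhibitor, a higher number a weaker inhibitor), > 10000 nM. That is the limit of > 10000 nM in this assay, at which 1 of the 3 values shown sits, so it offers a bound and not a number to step from.

Compound 4 `COc1cc(-c2ccnc3cc(-c4ccc(C(C)(C)C)cc4)nn23)cc(OC)c1OC` carries tert-butyl in place of ethoxycarbonyl on an aromatic carbon of a six-membered aromatic ring of carbon only, para to a large group: tert-butyl in place of ethoxycarbonyl on an aromatic carbon.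

Among the measured compounds shown here, two measured steps bear on this change. The closer one is an at least 9.4-fold higher number from compound 2 to compound 3 (0.97 log units; beyond the scatter), where ethoxycarbonyl came in for vinyl, starting from compound 2 `C=Cc1ccc(-c2cc3nccc(-c4cc(OC)c(OC)c(OC)c4)n3n2)cc1` at 1060 nM. Compound 1 `COc1cc(-c2ccnc3cc(-c4ccc5c(ccn5C)c4)nn23)cc(OC)c1OC` gives 39 nM in this assay. The other step, 4-vinylphenyl in place of 1-methyl-1H-indol-5-yl, is a 27-fold higher number from compound 1 to compound 2 (1.43 log units; beyond the scatter), and it is large. Compound 4 also lacks the 1-methyl-1H-indol-5-yl group, so on the evidence of a 27-fold higher number from compound 1 to compound 2 (1.43 log units; beyond the scatter) it is not expected to come close to the number of compound 1. With ethoxycarbonyl gone, an at least 9.4-fold higher number from compound 2 to compound 3 (0.97 log units; beyond the scatter) suggests a partial return towards the number of compound 2, though tert-butyl and vinyl are different groups and the data hold no direct comparison of them.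

The expected move is towards a lower number, of modest size: an at least 4.0-fold lower number from compound 3 to compound 4 (0.60 log units; beyond the scatter). For compound 4 the estimate is 2500 nM, with an expected range of 600 nM to 9000 nM.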

Compound 4, half-maximal inhibitory concentration: > 10000 nM
Compound 4: only a limit was reported; the forecaster's own chance of this, stated with the estimate: 15%; middle value at least 4.0-fold (0.60 log units) from the limit.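

In this assay compound 4 gives > 10000 nM, which is a limit of the assay and not a number. The step between the ethoxycarbonyl and tert-butyl compounds cannot be read, as both ends are limits, but tert-butyl in place of vinyl is an at least 9.4-fold higher number from compound 2 to compound 4 (0.97 log units; beyond the scatter), so the poor result of compound 3 does not depend on ethoxycarbonyl and its hydrogen-bond acceptors alone. Against the 1-methyl-1H-indol-5-yl group the change is an at least 250-fold higher number from compound 1 to compound 4 (2.40 log units; beyond the scatter), which widens the gap to that group, and compound 4 now joins compound 3 at the upper end of the assay: the limit of > 10000 nM in this assay, at which 2 of the 4 values shown sit.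

Going by these compounds, how compound 3 and compound 4 rank against each other stays open, and so does whether tert-butyl and ethoxycarbonyl differ at all at this place. Also open, on these data alone, is whether a small group such as an amine or a hydroxyl, para to the same large group, would restore a readable value, or whether the gain seen with compound 1 needs a fused ring system.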